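One More Dichlorophenyl Isomer in a Flat Series

The source may hold more compounds than are shown below. What is called first, only, known or untested is meant among the compounds shown, and "the series" means these compounds.

Of the compounds shown here, three sharing one core have been tested in a functional assay on HUVEC cells (Homo sapiens) for inhibition; a lower number here means a stronger inhibitor, a higher number a weaker inhibitor. Compound 1 (`COc1cc(/C=C/C(=O)c2cccc(NC(=O)c3c(Cl)cccc3Cl)c2)ccc1O`), which carries 2,6-dichlorophenyl on a carbonyl carbon, gives 0.46 ug/mL. Compound 2 (`COc1cc(/C=C/C(=O)c2cccc(NC(=O)c3ccco3)c2)ccc1O`), with furan-2-yl at that place, gives 0.38 ug/mL. Compound 3 (`COc1cc(/C=C/C(=O)c2cccc(NC(=O)c3ccc(Cl)cc3Cl)c2)ccc1O`), with 2,4-dichlorophenyl there, gives 0.4 ug/mL, a value within the scatter of both others.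

Compound 4 (`COc1cc(/C=C/C(=O)c2cccc(NC(=O)c3ccc(Cl)c(Cl)c3)c2)ccc1O`) is the next to be measured. It differs from compound 3 in a single group: 3,4-dichlorophenyl in place of 2,4-dichlorophenyl on a carbonyl carbon. In short, 3,4-dichlorophenyl stands in place of 2,4-dichlorophenyl on a carbonyl carbon.

Among the measured compounds shown here, the closest precedent is the exchange of one dichlorophenyl isomer for another, a 1.2-fold lower number from compound 1 to compound 3 (0.06 log units; within the scatter). The two exchanges involving furan-2-yl, a 1.2-fold lower number from compound 1 to compound 2 (0.08 log units; within the scatter) and a 1.1-fold higher number from compound 2 to compound 3 (0.02 log units; within the scatter), are equally small. From the compounds shown here alone, all three steps remain within the scatter, although none of the tested compounds carries 3,4-dichlorophenyl, so this group itself is untested. On this evidence, no step beyond the scatter is expected in this assay, and no direction can be favoured. The estimated step is a 1.1-fold higher number from compound 3 to compound 4 (0.02 log units; within the scatter), which would stay within the scatter. The value expected for compound 4 is 0.42 ug/mL, with an estimated range from 0.21 ug/mL to 0.85 ug/mL.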

Compound 4, half-maximal inhibitory concentration: 2.97 ug/mL
The estimate for compound 4 lay 7.1-fold (0.85 log units) below the measured number; the measured number lies above the stated range.
By their numbers in this assay, from the lowest: compounds 2, 3 and 1 (each within the scatter of the next); then compound 4.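

In this assay, among the compounds shown here, the place on the carbonyl carbon had so far taken furan-2-yl, 2,6-dichlorophenyl and 2,4-dichlorophenyl without any step beyond the scatter, but the new group shows that it is not indifferent to what sits there: the exchange gives (a 7.4-fold higher number from compound 3 to compound 4 (0.87 log units; beyond the scatter)), and the comparisons with the other two give (a 7.8-fold higher number from compound 2 to compound 4 (0.89 log units; beyond the scatter)) and (a 6.5-fold higher number from compound 1 to compound 4 (0.81 log units; beyond the scatter)). Compound 3 and compound 4 hold the same atoms, joined differently, and their groups match in every count given, so a rearrangement of the two chlorines alone separates a member of the flat set from the weakest inhibitor of the four, and dichlorophenyl as such does not fix the outcome. Nothing shown here offers an explanation for this step.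

The compounds shown leave open whether an unsubstituted phenyl or a phenyl carrying a single chlorine would fall with the first three compounds or with compound 4. They also leave open whether 3,4-dichlorophenyl would give a step of similar size on a core with the hydroxyl or methoxy group replaced.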